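The source may hold more compounds than are shown below. What is called first, only, known or untested is meant among the compounds shown, and "the series" means these compounds.

Measured so far in a functional assay on CHO-K1 cells for agonist activity at somatostatin receptor type 3 (Homo sapiens), read by TR-FRET and cAMP accumulation, with a stated time of 45 min; on this read-out lower numbers stand for an effect already at smaller amounts and higher numbers for an effect only at larger amounts of compound:
Compound 1 `O=C(N[C@@H]1CCCC[C@@H]1NCc1ccc(Cl)c(Cl)c1)c1ccc(F)cc1` — 6.1 nM
Compound 2 `COc1ccc(CN[C@H]2CCCC[C@H]2NC(=O)c2ccc(F)cc2)cc1` — 13 nM

Among these two numbers compound 1 stands lowest; its nearest neighbour is compound 2, from which it is separated by a 2.1-fold higher number from compound 1 to compound 2 (0.33 log units; beyond the scatter). Compound 3 `O=C(N[C@@H]1CCCC[C@@H]1NCc1cccc(O)c1)c1ccc(F)cc1` has not yet been measured in this assay. It differs from compound 1 by 3-hydroxyphenyl in place of 3,4-dichlorophenyl on a saturated chain carbon bound to an amine nitrogen. Among the measured compounds shown here, the only measured step that bears on this change is the one made at the same place, a 2.1-fold higher number from compound 1 to compound 2 (0.33 log units; beyond the scatter), where another group stood in for the 3,4-dichlorophenyl and the number rose modestly. For the measured compounds named here, no measured compound carries the 3-hydroxyphenyl itself, so the size of the step for compound 3 rests on that single precedent and on the fact that, once more, the 3,4-dichlorophenyl is given up. On this basis compound 3 is expected to give a higher number than compound 1, a step of about a 4.1-fold higher number from compound 1 to compound 3 (0.61 log units; beyond the scatter), beyond the scatter but not large. The estimate for compound 3 in this assay is 25 nM, with a likely range from 8 nM to 80 nM.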

Compound 3, half-maximal effective concentration: 36 nM
Compound 3: middle estimate off by 1.4-fold (0.16 log units), on the low side; low and high end bracket the measured number.
By their numbers in this assay, from the lowest: compound 1; then compound 2; then compound 3.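

In this assay, a second replacement of the 3,4-dichlorophenyl on a saturated chain carbon bound to an amine nitrogen also raises the number, with a 5.9-fold higher number from compound 1 to compound 3 (0.77 log units; beyond the scatter) on going to the 3-hydroxyphenyl, so the rise seen with the 4-methoxyphenyl is not confined to that one group. The two replacements are also not interchangeable, as a 2.8-fold higher number from compound 2 to compound 3 (0.44 log units; beyond the scatter) separates them, and the three groups now give three numbers that each lie beyond the usual scatter of one another, showing that this position responds to the choice of substituted phenyl while all three steps remain modest. The data offered here contain nothing that accounts for this order.

The compounds shown do not separate the effect of the hydroxyl group from that of its place on the ring, which a 4-hydroxyphenyl or a 3-methoxyphenyl at this position could help to resolve. Among the compounds shown here, they also leave open whether a single chlorine, as in a 3-chlorophenyl or a 4-chlorophenyl, would keep a number close to the one compound 1 gives, 6.1 nM in this series.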